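Removing the methoxymethoxy group from compound 1

The source may report more compounds than this note shows. Statements on the series, on what has been measured and on what is new or still open speak of the compounds shown alone.

Compound 1 `C=C1C=CC(=O)[C@@H]2[C@H](Cc3ccc(OCOC)cc3)CC[C@H]12` gives 219 nM
Compound 2 `C=C1C=CC(=O)[C@@H]2[C@H](Cc3ccc(OCOC)c(F)c3)CC[C@H]12` gives 75.7 nM

Both values come from a functional assay on COLO 205 cells (Homo sapiens) for antiproliferative activity, with a stated time of 72 h (a higher number here means a weaker inhibitor, a lower number a stronger inhibitor), and compound 1 holds the higher of the two numbers, which makes it the weaker inhibitor of this pair. Compound 3 `C=C1C=CC(=O)[C@@H]2[C@H](Cc3ccccc3)CC[C@H]12` differs from compound 1 in one place, with hydrogen in place of methoxymethoxy on an aromatic carbon. Within the data shown here, only one measured step bears on this, fluoro in place of hydrogen on an aromatic carbon, and it gave a 2.9-fold lower number from compound 1 to compound 2 (0.46 log units; beyond the scatter) as a modest change. That step shows that a single edit on this aromatic ring can move the number beyond the scatter. It leaves the methoxymethoxy in place, however, so the data give no direction for its removal. A step of similar size could go either way, and the central expectation in this assay is no clear shift. The estimated change is a 1.1-fold higher number from compound 1 to compound 3 (0.04 log units; within the scatter) and the range stays wide. Compound 3 is therefore estimated at 240 nM (expected range 75 nM to 750 nM).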

Compound 3, half-maximal inhibitory concentration: 547 nM
For compound 3 the middle estimate is 2.3-fold (0.36 log units) below the measured one, and the stated range covers the measured number.
By their numbers in this assay, from the lowest: compound 2; then compound 1; then compound 3.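

In this assay, replacing the methoxymethoxy group with hydrogen on the aromatic ring gives a 2.5-fold higher number from compound 1 to compound 3 (0.40 log units; beyond the scatter), so the substituent at this place, para to a large group, does affect the result. The earlier fluoro step left this group untouched and gave no direction for its removal, whereas this step gives one: for this pair, the compound that keeps methoxymethoxy is the stronger inhibitor and the one with the bare ring is the weaker. No available evidence explains why the number rises, so this result records the size and direction of the change but not its cause.

As far as these compounds go, it remains open whether a smaller group at this place, such as methoxy or hydroxyl, would keep the lower number of compound 1, and whether an amine, a carboxylic acid or a longer chain such as butoxy would match it. Also open, from the compounds shown here alone, is whether adding fluoro to the bare ring of compound 3 would lower the number as it did when methoxymethoxy was present.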